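From Anilino to Benzylamino: Weighing a Single Change

The source may hold more compounds than are shown below. What is called first, only, known or untested is meant among the compounds shown, and "the series" means these compounds.

Compound 1 `OC[C@H]1OC(n2cnc3c(Nc4ccccc4)nccc32)[C@H](O)[C@@H]1O`: 10%
Compound 2 `OC[C@H]1O[C@@H](n2cnc3c(Cl)nccc32)C[C@@H]1O`: < 5%
Compound 3 `CSc1nccc2c1ncn2[C@H]1C[C@H](O)[C@@H](CO)O1`: < 5%

For the measured compounds named here, in a functional assay on EL4 cells (Mus musculus) for inhibition, tested at 100 uM (on this read-out lower numbers stand for less inhibition and higher numbers for more inhibition at the one concentration tested (going by the name of the read-out)), compound 1 gives 10%, the only number among the three measured compounds. Compound 2 gives < 5%, which is a limit of the assay and not a number. Compound 3 likewise gives < 5%, again a limit. The step that the two limits leave unreadable from compound 2 to compound 3 is therefore of unreadable size. Compound 1 stands apart because of the limit of < 5% in this assay, at which 2 of the 3 values shown sit.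

Compound 4 `OC[C@H]1OC(n2cnc3c(NCc4ccccc4)nccc32)[C@H](O)[C@@H]1O` differs from compound 1 by benzyl in place of phenyl on a nitrogen on an aromatic ring. Going by the values given here, no measured step involves this change; the one step on record concerns a different exchange and is unreadable. With nothing to point either way, the expected step of no change at the digits printed from compound 1 to compound 4 (within the scatter) is none beyond the scatter. Compound 4 is therefore expected to give 10%, between 0% and 25%, in this assay.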

Compound 4, a percentage reported as inhibition, at one concentration (the size of the read-out at that concentration, not a potency): 5%
The estimate for compound 4 lay 5 percentage points above the measured number; measured number inside the range.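

Benzyl in place of phenyl on a nitrogen on an aromatic ring gives a number 5 percentage points lower from compound 1 to compound 4 (within the scatter) in this assay. For the compounds shown here, this is the first step in the set that can be read, and it shows that anilino and benzylamino on this nitrogen cannot be told apart at the one concentration tested. The room for reading any step here is also small: the limit of < 5% in this assay, at which 2 of the 4 values shown sit.

Still open, from the compounds shown here alone, is whether a longer chain such as phenethyl on this nitrogen would give a step beyond the scatter. The same holds for a carboxylic acid on the benzyl ring.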